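Swapping the Five-Membered Ring: From Compound 2 to Compound 3

A few compounds are considered here, and "the series" means these few. Any claim that something is new, unique, unknown or untested is made for them only; others in the source may bear on it.

Compound 1 `Fc1ccc2nc(-n3ccnn3)n(C3CC3)c2c1`: 9070 nM
Compound 2 `Fc1ccc2nc(-c3cnco3)n(C3CC3)c2c1`: > 10000 nM

In an ADME assay on cells for inhibition of cytochrome P450 11B1, mitochondrial (Homo sapiens), read by HPLC, with a stated time of 60 min (on this read-out lower numbers stand for stronger inhibition and higher numbers for weaker inhibition), compound 1 gives 9070 nM. For compound 2 the read-out is > 10000 nM, a limit of the assay rather than a number, so compound 2 stands at the weak edge of what is shown (the limit of > 10000 nM in this assay, at which 1 of the 2 values shown sits). Compound 3 `Fc1ccc2nc(-c3cn[nH]c3)n(C3CC3)c2c1` differs from compound 2 by 1H-pyrazol-4-yl in place of 1,3-oxazol-5-yl on an aromatic carbon. Within the data shown here, only one measured step bears on this: an at least 1.1-fold higher number from compound 1 to compound 2 (0.04 log units; that floor lies within the scatter), also a swap of one five-membered ring for another, and within the scatter. A similar small shift is expected here. Compound 3 is estimated at 9000 nM, with a range from 3000 nM to 30000 nM. The expected step is an at least 1.1-fold lower number from compound 2 to compound 3 (0.04 log units; that floor lies within the scatter), and a second limit read-out would not be surprising.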

Compound 3, half-maximal inhibitory concentration: 1670 nM
Compound 3: the middle estimate sits 5.4-fold (0.73 log units) above what was measured; measured number below the stated range.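

Five-membered rings of the same size on this aromatic carbon need not behave alike in this assay, since the earlier swap showed no step beyond the scatter, while 1H-pyrazol-4-yl gives an at least 5.9-fold lower number from compound 2 to compound 3 (0.77 log units; beyond the scatter) and also a 5.4-fold lower number from compound 1 to compound 3 (0.73 log units; beyond the scatter). Compound 2 reads > 10000 nM, a limit of the assay and not a number, so its step is only a floor. Nothing given here explains the difference.

Still open, going by these compounds, is whether a methyl group on the 1H-pyrazol-4-yl, or a simple amine in place of the ring, would keep this gain.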